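The compounds below may be only part of what the source reports. "The series", "measured", "known", "first", "only" and "open" are said of these compounds alone.

In a functional assay on CHO cells for antagonist activity at sphingosine 1-phosphate receptor 2 (Homo sapiens), read by GTPgammaS binding (a lower number here means a stronger inhibitor, a higher number a weaker inhibitor), compound 1 `CC(C(=O)O)c1nn(Cc2cn3cc(OCC4CC4)c(Cl)cc3n2)c2ccccc2c1=O` gives 31 nM. Among the three compounds with a measured number, compound 1 stands second highest. Compound 2 `O=C(O)Cc1nn(Cc2cn3cc(OCC4CC4)c(Cl)cc3n2)c2ccccc2c1=O` gives 30 nM, and the step of a 1.0-fold lower number from compound 1 to compound 2 (0.01 log units; within the scatter) lies within the scatter, so the two cannot be ranked against each other. Compound 3 `O=C(O)C1(c2nn(Cc3cn4cc(OCC5CC5)c(Cl)cc4n3)c3ccccc3c2=O)CC1` gives 82 nM; the step of a 2.6-fold higher number from compound 1 to compound 3 (0.42 log units; beyond the scatter) is modest but beyond the scatter, as is the step of a 2.7-fold higher number from compound 2 to compound 3 (0.44 log units; beyond the scatter).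

Compound 4 `CC(C(=O)O)c1nn(Cc2cn3cc(OCC4CC4)c(C(F)(F)F)cc3n2)c2ccccc2c1=O` has not yet been measured in this assay. It differs from compound 1 by trifluoromethyl in place of chloro on an aromatic carbon. Among the compounds with values here, all three measured steps change the acid-bearing group on the shared core and leave the chloro untouched, so no measured step bears on the change from compound 1 to compound 4. Within the data shown here, the only anchor is compound 1 itself at 31 nM. In the absence of any comparable step, the expectation is for no step beyond the scatter in either direction, with a wide range to allow for a change of unknown size. Compound 4 is estimated at 31 nM, between 8 nM and 120 nM. This expectation amounts to a step of no change at the digits printed from compound 1 to compound 4 (within the scatter).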

Compound 4, half-maximal inhibitory concentration: 51 nM
The estimate for compound 4 lay 1.6-fold (0.22 log units) below the measured number; low and high end bracket the measured number.
By their numbers in this assay, from the lowest: compounds 2, 1, 4 and 3 (each within the scatter of the next, the first and the last beyond it).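

This is the first change shown on the aromatic carbon ortho to a cyclopropylmethoxy group, away from the acid-bearing group, and in this assay the step is a 1.6-fold higher number from compound 1 to compound 4 (0.22 log units; within the scatter). With the 1-carboxyethyl group held in place, trifluoromethyl with its 4 heavy atoms can therefore replace chloro with its 1 heavy atom at this position, and the two compounds cannot be ranked against each other. Nothing measured here accounts for this result, so it stands as an observation without a stated cause.

Trifluoromethyl is shown only alongside the 1-carboxyethyl group, so it remains open whether the swap would read the same with the carboxymethyl group of compound 2 or the 1-carboxycyclopropyl group of compound 3. On these data alone, it also remains open how far the position accepts other groups, such as hydrogen, methyl, bromo, methoxy or a nitrile, and whether any of them would move the number beyond the scatter in either direction.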